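Cytotoxicity of two quinazoline ethers and a chloro analogue

This account rests on a few compounds, and the source may have more. Where it says the series, first, only, none or still open, it means among the compounds named here.

Compounds measured so far:
compound 1 `CCOc1cc(C#N)cc(OCC)c1Oc1nc(Nc2ccc(C#N)cc2)nc2ccccc12` — 108000 nM
compound 2 `COc1ccc(Oc2nc(Nc3ccc(C#N)cc3)nc3ccccc23)cc1` — 340000 nM

In an ADME assay on MT4 cells (Homo sapiens) for cytotoxicity, read by MTT assay, with a stated time of 4 days (on this read-out higher numbers stand for lower toxicity in this test and lower numbers for higher toxicity in this test), compound 2 gives 340000 nM, the highest of the two numbers recorded. Its nearest neighbour is compound 1, whose value in this assay is lower by a margin that lies beyond the scatter, so compound 2 is the less toxic of the pair on this read-out. Compound 3 `N#Cc1ccc(Nc2nc(Oc3ccc(Cl)cc3)c3ccccc3n2)cc1` has not yet been measured. It differs from compound 2 in a single place: chloro in place of methoxy on an aromatic carbon. Among the measured compounds shown here, no pair among the measured compounds shows this exchange, so the data give no direct guide to its size. With a single atom replacing a two-atom group on the same aromatic carbon, the step from compound 2 to compound 3 is expected to be small, in either direction, and probably not beyond the scatter, which is what a 1.4-fold lower number from compound 2 to compound 3 (0.13 log units; within the scatter) means. Compound 3 is therefore estimated at 250000 nM, within a range of 80000 nM to 600000 nM.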

Compound 3, half-maximal cytotoxic concentration: 198000 nM
Beside the measured number, compound 3's estimate is 1.3-fold (0.10 log units) above it; the measured number falls inside the stated range.
By their numbers in this assay, from the lowest: compounds 1, 3 and 2 (each within the scatter of the next, the first and the last beyond it).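

Going from 4-methoxyphenoxy to 4-chlorophenoxy in this assay gives a 1.7-fold lower number from compound 2 to compound 3 (0.23 log units; within the scatter) and so provides the first direct reading of a single change in this set. On an aromatic carbon para to a large group, this read-out does not separate chloro from methoxy, even though the exchange replaces a group of 2 heavy atoms, including a hydrogen-bond acceptor, with a single chlorine atom. Nothing available accounts for the size of this step.

Going by these compounds, what an amine, a carboxylic acid or a longer chain would do at this place remains open. Among the compounds shown here, also open is whether the same exchange would give a step of similar size on a ring that carries other groups, like the one in compound 1.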